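Aryl exchange on the shared core: compound 2 to compound 3

The source may report more compounds than this note shows. Statements on the series, on what has been measured and on what is new or still open speak of the compounds shown alone.

In a functional assay on KYSE-70 cells for antiproliferative activity against KYSE-70 cell line (Homo sapiens), read by MTT assay, with a stated time of 72 h (on this read-out lower numbers stand for stronger inhibition and higher numbers for weaker inhibition), compound 1 `O=C(Nc1cccc(F)c1)c1cc(=O)[nH]c2cc(-c3ccc(F)cc3)ccc12` gives 3300 nM. Compound 2 `Cc1ccc(-c2ccc3c(C(=O)Nc4cccc(F)c4)cc(=O)[nH]c3c2)cc1` reads > 20000 nM, which is a limit of the assay and not a number. Compound 2 therefore has no exact position, and any comparison with it has a limit on one side.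

Compound 3 `O=C(Nc1cccc(F)c1)c1cc(=O)[nH]c2cc(-c3cccnc3F)ccc12` replaces the 4-methylphenyl of compound 2 with 2-fluoropyridin-3-yl on an aromatic carbon of the shared core: 2-fluoropyridin-3-yl in place of 4-methylphenyl on an aromatic carbon.

Among the compounds with values here, only one measured step bears on this change: an at least 6.0-fold higher number from compound 1 to compound 2 (0.78 log units; beyond the scatter). That step put methyl in place of fluoro, while the move to compound 3 removes the methyl and brings in a fluoro on a ring with a hetero atom. Within the data shown here, the precedent is therefore indirect, as no measured compound carries this ring. Even so, compound 3 is expected to move back toward compound 1 at 3300 nM, without clearly passing it, and a lower number than in this assay for compound 2 is expected.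

The estimated change is an at least 3.3-fold lower number from compound 2 to compound 3 (0.52 log units; beyond the scatter). For compound 3 the expected value is 6000 nM, with an estimated range of 2000 nM to 20000 nM.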

Compound 3, half-maximal inhibitory concentration: > 20000 nM
Compound 3 gave a limit, no number (the forecaster's own chance of this, stated with the estimate: 25%); middle value at least 3.3-fold (0.52 log units) from the limit.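

In this assay compound 3 reads > 20000 nM, which is a limit of the assay and not a number. Placing 2-fluoropyridin-3-yl at this aromatic carbon in place of the 4-fluorophenyl of compound 1 gives an at least 6.0-fold higher number from compound 1 to compound 3 (0.78 log units; beyond the scatter), so a fluoro on the incoming ring is not enough to keep a readable value, and among the compounds shown only the 4-fluorophenyl group gives one. The step from compound 2 to compound 3 cannot be read, and no order between 4-methylphenyl and 2-fluoropyridin-3-yl can be drawn, because both compounds sit at the assay's ceiling: the limit of > 20000 nM in this assay, at which 2 of the 3 values shown sit.

Still open, on these data alone, is whether the ring nitrogen or the place of the fluoro accounts for the difference from compound 1, a question that 2-fluorophenyl or unsubstituted pyridin-3-yl at this carbon would help to separate. Also open, as far as these compounds go, is whether any group at this carbon goes beyond compound 1 at 3300 nM, for instance 4-chlorophenyl, 4-methoxyphenyl or a phenyl ring carrying an amine or a carboxylic acid.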